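Compound 4 against the limit of the series

The compounds below may be only part of what the source reports. "The series", "measured", "known", "first", "only" and "open" are said of these compounds alone.

In a functional assay on BaF3 cells (Mus musculus) for inhibition, read by MTT assay, with a stated time of 3 days (on this read-out higher numbers stand for weaker inhibition of growth and lower numbers for stronger inhibition of growth), compound 1 `O=C(Nc1ccc(Nc2ncnc3c2OCCN3)cc1)Nc1ccc(Cl)c(C(F)(F)F)c1` reads > 10000 nM, which is a limit. As far as these compounds go, compound 3 `COc1ccc(NC(=O)Nc2ccc(Nc3ncnc4c3OCCN4)cc2)cc1` reads > 10000 nM, also a limit and not a number, so its exact place is unknown. Compound 2 `O=C(Nc1ccc(Br)cc1)Nc1ccc(Nc2ncnc3c2OCCN3)cc1` gives 10000 nM. The series therefore sits close to the limit of > 10000 nM in this assay, at which 2 of the 3 values shown sit.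

Compound 4 `O=C(Nc1ccc(Nc2ncnc3c2OCCN3)cc1)Nc1cc(Cl)cc(Cl)c1` differs from compound 3 by 3,5-dichlorophenyl in place of 4-methoxyphenyl on an amide-type nitrogen, with 3,5-dichlorophenyl in place of 4-methoxyphenyl on an amide-type nitrogen. For the measured compounds named here, the one measured step that bears on this, a number no lower from compound 2 to compound 3 (the limit leaves the size open), has a size left open by the limit. No clear move away from the limit is expected in this assay, and the expected step is an at least 1.1-fold lower number from compound 3 to compound 4 (0.04 log units; that floor lies within the scatter). For compound 4 the estimate is 9000 nM, with an expected range of 3000 nM to 20000 nM.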

Compound 4, concentration for 50% growth inhibition: 10000 nM
The estimate for compound 4 lay 1.1-fold (0.05 log units) below the measured number, within the range that was stated.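

On the amide-type nitrogen, 3,5-dichlorophenyl in place of 4-bromophenyl gives the following in this assay (no change at the digits printed from compound 2 to compound 4 (within the scatter)). With 3,5-dichlorophenyl in place of 4-methoxyphenyl on the same nitrogen, the result is a number no higher from compound 3 to compound 4 (the limit leaves the size open) and its size cannot be read, as compound 3 carries only a limit. The series thus stays at the edge of the read-out: the limit of > 10000 nM in this assay, at which 2 of the 4 values shown sit.

Still open, as far as these compounds go, is whether any group on this nitrogen moves the read-out clear of that limit. In this assay the compounds shown do not tell how a phenyl ring carrying a carboxylic acid or a dimethylamino group, or a longer alkyl chain in its place, would read.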